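This account rests on a few compounds, and the source may have more. Where it says the series, first, only, none or still open, it means among the compounds named here.

Compound 1, `COc1ccc(N(C)c2nc(C)nc3ccccc23)cc1C(=O)OCCC[Se]C#N`, gives 854 nM in a functional assay on LoVo cells (Homo sapiens) for inhibition, read by MTT assay, with a stated time of 48 h; a lower number here means a stronger inhibitor, a higher number a weaker inhibitor.
Compound 2, `COc1ccc(N(C)c2nc(C)nc3ccccc23)cc1C(=O)OCCCC[Se]C#N`, gives 1080 nM in this assay.
Compound 3, `COc1ccc(N(C)c2nc(C)nc3ccccc23)cc1[Se]C#N`, gives 73 nM in this assay.

Compound 3 stands lowest of the three numbers in this assay and is the strongest inhibitor here, since a 12-fold lower number from compound 1 to compound 3 (1.07 log units; beyond the scatter) and a 15-fold lower number from compound 2 to compound 3 (1.17 log units; beyond the scatter) both lie beyond the scatter. Between compound 1 and compound 2, by contrast, a 1.3-fold higher number from compound 1 to compound 2 (0.10 log units; within the scatter) stays within the scatter.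

Compound 4, `COc1ccc(N(C)c2nc(C)nc3ccccc23)cc1OCCCC[Se]C#N`, is obtained from compound 3 by the change (a group of 8 heavy atoms (5 carbon, 1 nitrogen, 1 oxygen, 1 selenium; no ring) in place of a group of 3 heavy atoms (1 carbon, 1 nitrogen, 1 selenium; no ring), on an aromatic carbon). The selenium-bearing group is thus moved off the aromatic carbon onto a chain, now linked through an oxygen rather than through an ester. For the measured compounds named here, the steps that bear on this are a 12-fold lower number from compound 1 to compound 3 (1.07 log units; beyond the scatter) and a 15-fold lower number from compound 2 to compound 3 (1.17 log units; beyond the scatter), both large, and both run the opposite way to the change now made. A large rise in the number is therefore expected for compound 4 in this assay, about an 11-fold higher number from compound 3 to compound 4 (1.04 log units; beyond the scatter). Compound 4 is estimated at 800 nM, in the range 250 nM to 2500 nM.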

Compound 4, half-maximal inhibitory concentration: 882 nM
Beside the measured number, compound 4's estimate is 1.1-fold (0.04 log units) below it; the measured number falls inside the stated range.
By their numbers in this assay, from the lowest: compound 3; then compounds 1, 4 and 2 (each within the scatter of the next).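

At this aromatic carbon ortho to a methoxy group, a 12-fold higher number from compound 3 to compound 4 (1.08 log units; beyond the scatter) in this assay shows that the large loss seen with the ester-linked chains also appears when the chain is linked through an oxygen. The link itself makes no visible difference here: a 1.0-fold higher number from compound 1 to compound 4 (0.01 log units; within the scatter) and a 1.2-fold lower number from compound 2 to compound 4 (0.09 log units; within the scatter) both stay within the scatter, so in these compounds the directly attached selenium-bearing group stands apart from all three chain-bearing compounds, whichever of the two links they carry. The data offered here include no evidence that would explain this result.

The compounds shown leave open how a shorter or longer chain on the oxygen, or an amine as the link, would read in this assay. They also leave open whether sulfur in place of selenium would keep the low number of compound 3.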